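Trimming the 4-Methoxybenzyl Group Back to Ethyl

The source may report more compounds than this note shows. Statements on the series, on what has been measured and on what is new or still open speak of the compounds shown alone.

Compound 1 `COc1ccc(Cn2c(=O)n(C3OC(CO)[C@@H](O)[C@H]3O)c3nc(N)nc(O)c32)cc1`: 135 uM
Compound 2 `Nc1nc(O)c2c(n1)n(C1OC(CO)[C@@H](O)[C@H]1O)c(=O)n2Cc1ccc(OCc2ccccc2)cc1`: 8 uM

Both numbers come from a functional assay (B cells) with Mus musculus as the target; a higher number here means that more compound is needed for the effect, a lower number that less compound is needed. Compound 1 has the highest of the two; its nearest neighbour is compound 2, reached by a 17-fold lower number from compound 1 to compound 2 (1.23 log units; beyond the scatter). Compound 3 `CCn1c(=O)n(C2OC(CO)[C@@H](O)[C@H]2O)c2nc(N)nc(O)c21` is not yet measured; its change from compound 1 is methyl in place of 4-methoxyphenyl on a saturated chain carbon bound to an aromatic nitrogen. Within the data shown here, the single measured step bears on this only in reverse: growing the group on that side of the shared core gave a 17-fold lower number from compound 1 to compound 2 (1.23 log units; beyond the scatter), so cutting it back is expected to move the number the other way, beyond the scatter. Compound 3 is therefore estimated at 450 uM, within 150 uM to 1500 uM, which means a 3.3-fold higher number from compound 1 to compound 3 (0.52 log units; beyond the scatter).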

Compound 3, concentration for half-maximal effect: 15 uM
Estimate against measurement, compound 3: 30-fold (1.48 log units) above, outside the stated range (below it).
By their numbers in this assay, from the lowest: compounds 2 and 3 (each within the scatter of the next); then compound 1.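

In this assay, trimming 4-methoxybenzyl back to ethyl gave a 9.0-fold lower number from compound 1 to compound 3 (0.95 log units; beyond the scatter) at this position, so a smaller group here does not raise the number. Among these compounds, compound 1 is the one with the highest number, since growing it at the far end, as in compound 2, and cutting it back, as in compound 3, both lower the number. Nothing measured here explains this shift. Still open, on these data alone, is how a propyl chain or a plain benzyl group would behave at this position, and whether an amine on the chain would be tolerated.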